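Compound 2 to compound 4: a change at the carbonyl

The source may report more compounds than this note shows. Statements on the series, on what has been measured and on what is new or still open speak of the compounds shown alone.

Compound 1 `COc1cc(Cl)cc(-c2nn(-c3cccc(NC(=O)Nc4cccc(C(F)(F)F)c4)c3)cc2-c2ccncc2)c1`: 6.89%
Compound 2 `COc1cc(Cl)cc(-c2nn(-c3cccc(NC(=O)Nc4ccc(Cl)c(C(F)(F)F)c4)c3)cc2-c2ccncc2)c1`: -14.4%
Compound 3 `COc1cc(Cl)cc(-c2nn(-c3cccc(NC(=O)c4cc(C(F)(F)F)cc(C(F)(F)F)c4)c3)cc2-c2ccncc2)c1`: 46.5%

In a functional assay on MDA-MB-468 cells (Homo sapiens) for inhibition, read by sulforhodamine B assay, with a stated time of 48 h, tested at 10 uM (on this read-out higher numbers stand for a weaker effect at the one concentration tested and lower numbers for a stronger effect), compound 2 stands lowest of the three, which on this read-out means the strongest effect at the one concentration tested; compound 1 lies above it beyond the scatter, and compound 3 further above still. Going by the values given here, the only step measured between compounds differing in one place, a number 21.3 percentage points lower from compound 1 to compound 2 (beyond the scatter), is modest. Compound 4 `COc1cc(Cl)cc(-c2nn(-c3cccc(NC(=O)c4ccc(Cl)c(Cl)c4)c3)cc2-c2ccncc2)c1` has not been measured yet. It differs from compound 2 in this way: 3,4-dichlorophenyl in place of (4-chloro-3-(trifluoromethyl)phenyl)amino on a carbonyl carbon. Among the compounds with values here, no measured step mirrors this exchange. The nearest guide is compound 3, which likewise carries an aromatic ring directly on the carbonyl carbon rather than an amino group; in this assay compound 3 gives 46.5%, far above compound 2. On that basis compound 4 is expected to show a weaker effect than compound 2, so the step of a number 44.4 percentage points higher from compound 2 to compound 4 (beyond the scatter) is expected to be upward and beyond the scatter. Compound 4 is therefore estimated at 30%, within 0% to 60%.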

Compound 4, a percentage reported as activity, at one concentration (the size of the read-out at that concentration, not a potency): 54.6%
Estimate against measurement, compound 4: 24.6 percentage points below; the range from low to high includes it.
By their numbers in this assay, from the lowest: compound 2; then compound 1; then compounds 3 and 4 (each within the scatter of the next).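

Placing 3,4-dichlorophenyl directly on the carbonyl carbon, in place of an aryl amino group, costs a large part of the effect in this assay from both starting points, giving a number 69 percentage points higher from compound 2 to compound 4 (beyond the scatter) and also a number 47.7 percentage points higher from compound 1 to compound 4 (beyond the scatter) with the chloro-free amino group as the one replaced. Compound 3 and compound 4 lie within the scatter of each other, so these two different aromatic rings on the carbonyl carbon read alike. No measurement here explains why the effect falls.

Both steps change the amino nitrogen and the ring substituents at once, so the compounds shown cannot divide the loss between them. Also open, from the compounds shown here alone, is how a non-aromatic group on the carbonyl carbon, such as cyclohexyl or ethylamino, would read in this assay.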